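The source may hold more compounds than are shown below. What is called first, only, known or untested is meant among the compounds shown, and "the series" means these compounds.

Measured so far:
compound 1, `COc1cccc(OC)c1OCCNCCOc1ccccc1OCc1cccc(C)c1`, 8.2
compound 2, `COc1cccc(OC)c1OCCNCCOc1ccccc1OCc1ccccc1[N+](=O)[O-]`, 8.56
compound 3, `COc1cccc(OC)c1OCCNCCOc1ccccc1OCc1cccc([N+](=O)[O-])c1`, 8.74

All three were run in a functional assay on spleen for antagonist activity at Alpha-1B adrenergic receptor (Rattus norvegicus); a higher number here means a more potent compound, by a factor of ten per unit of this negative logarithm, a lower number a less potent compound. Compound 3 holds the highest of the three numbers, but its nearest neighbour is compound 2, and that gap, a number 0.18 log units higher from compound 2 to compound 3 (within the scatter), does not separate the two. Against compound 1 the gap is clear: a number 0.54 log units higher from compound 1 to compound 3 (beyond the scatter). Compound 2 shows the same tendency, a number 0.36 log units higher from compound 1 to compound 2 (beyond the scatter). In this small set a nitro on the benzyl ring, in either of the two positions tried, gives a higher number than the methyl of compound 1; nothing else has been varied.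

Compound 4, `COc1cccc(COc2ccccc2OCCNCCOc2c(OC)cccc2OC)c1`, has not yet been measured. It differs from compound 3 by methoxy in place of nitro on an aromatic carbon. For the measured compounds named here, no measured pair touches a methoxy at this position, so the only step that bears on it is the methyl-to-nitro change, a number 0.54 log units higher from compound 1 to compound 3 (beyond the scatter), a modest gain that compound 4 gives up. The expectation is that compound 4 lands somewhere between compound 1 and compound 3, a loss from compound 3 of about a number 0.34 log units lower from compound 3 to compound 4 (beyond the scatter) in this assay, which may not clear the scatter. Compound 4 is estimated at 8.4, with a range of 7.9 to 8.9.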

Compound 4, negative logarithm of the antagonist equilibrium constant: 8.31
Beside the measured number, compound 4's estimate is 0.09 log units above it; measured number inside the range.
By their numbers in this assay, from the lowest: compounds 1, 4, 2 and 3 (each within the scatter of the next, the first and the last beyond it).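

In this assay, the nitro of compound 3 cannot be swapped for methoxy at this place, meta to a large group, without a loss: a number 0.43 log units lower from compound 3 to compound 4 (beyond the scatter). Methoxy does not separate from methyl here, a number 0.11 log units higher from compound 1 to compound 4 (within the scatter), so among the groups shown at this place, the higher number goes with nitro rather than with any group other than methyl. Compound 4 and compound 2 also stay unseparated, a number 0.25 log units lower from compound 2 to compound 4 (within the scatter), although they carry different groups at different places on the ring, and nothing available here explains why nitro and methoxy part at this place.

As far as these compounds go, whether the higher number stays with nitro alone or also appears with a nitrile, a trifluoromethyl, an amine or a carboxylic acid at this place remains open. Also open, from the compounds shown here alone, is whether a methoxy at the place held by the nitro of compound 2 would give a number close to that of compound 4, and whether the step from nitro to methoxy carries over when the shared core is changed.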